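Changing a ring hydrogen to methyl on the sulfonamide aniline

This account rests on a few compounds, and the source may have more. Where it says the series, first, only, none or still open, it means among the compounds named here.

Measured compounds and their values:
Compound 1, `O=C(/C=C/c1cccnc1)NCCCc1ccc(S(=O)(=O)Nc2ccccc2)cc1`, gives 5920 nM in an assay on isolated protein for inhibition of Nicotinamide phosphoribosyltransferase (Homo sapiens), read by WST assay, with stated times of 60 min, 5 min and 30 min, in the presence of a further agent that is not named here; a lower number here means a stronger inhibitor, a higher number a weaker inhibitor.
Compound 2, `O=C(/C=C/c1cccnc1)NCCCCCCc1cccc(S(=O)(=O)Nc2ccccc2)c1`, gives 10.5 nM in this assay.
Compound 3, `O=C(/C=C/c1cccnc1)NCCCCCCCc1cccc(S(=O)(=O)Nc2ccccc2)c1`, gives 31.3 nM in this assay.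

Among these three numbers compound 2 stands lowest, which here means it is the strongest inhibitor of the set. Its nearest neighbour is compound 3, whose number lies higher by a margin beyond the scatter, and compound 1 lies far above both.

Compound 4, `Cc1ccccc1NS(=O)(=O)c1cccc(CCCCCCNC(=O)/C=C/c2cccnc2)c1`, is not yet measured. It differs from compound 2 in one place: methyl in place of hydrogen on an aromatic carbon. In words, a methyl takes the place of a hydrogen on an aromatic carbon of a six-membered aromatic ring of carbon only, ortho to a large group, so that the phenylsulfamoyl end becomes (2-methylphenyl)sulfamoyl.

For the measured compounds named here, no measured pair in this set shows this kind of change, so there is no step to lean on. A single small group added to the anilide ring is expected to move the number only modestly in this assay, in either direction, quite possibly not beyond the scatter. The estimate for compound 4 is therefore 15 nM, with a range from 4 nM to 60 nM, which means an expected step of a 1.4-fold higher number from compound 2 to compound 4 (0.15 log units; within the scatter).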

Compound 4, half-maximal inhibitory concentration: 5.08 nM
Compound 4: the middle estimate sits 3.0-fold (0.47 log units) above what was measured; measured number inside the range.
By their numbers in this assay, from the lowest: compound 4; then compound 2; then compound 3; then compound 1.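

Compounds 1, 2 and 3 all carry the same plain phenylsulfamoyl end, so they said nothing about whether that ring can take a substituent. Here, in this assay, the change to (2-methylphenyl)sulfamoyl gives a 2.1-fold lower number from compound 2 to compound 4 (0.32 log units; beyond the scatter): the step is modest, but it shows that a methyl on this aromatic carbon, ortho to a large group, is accepted with a small gain rather than a loss. No measurement shown here accounts for this gain, so the step stands as an observation without an explanation.

This single methyl leaves open whether the same ring would respond similarly to an ethyl, a chlorine or a methoxy group in this place, or to a methyl on another of its carbons. It also leaves open whether the same methyl would give a similar step on the longer chain of compound 3, or whether the small gain belongs only to the chain of compound 2.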